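Piperazin-1-yl for 4-methoxyphenyl, starting from a limit

The source may hold more compounds than are shown below. What is called first, only, known or untested is meant among the compounds shown, and "the series" means these compounds.

Measured in a functional assay on MDA-MB-231 cells (Homo sapiens) for inhibition, read by MTT assay, with a stated time of 72 h; a lower number here means a stronger inhibitor, a higher number a weaker inhibitor:
compound 1 `CC(C)(C)n1cc2c(n1)C(=O)CC1(CCN(C(=O)c3cc(-c4ccccc4)nc4ccccc34)CC1)O2`: > 10000 nM
compound 2 `COc1ccc(-c2cc(C(=O)N3CCC4(CC3)CC(=O)c3nn(C(C)(C)C)cc3O4)c3ccccc3n2)cc1`: > 10000 nM
compound 3 `CN(C)c1ccc(-c2cc(C(=O)N3CCC4(CC3)CC(=O)c3nn(C(C)(C)C)cc3O4)c3ccccc3n2)cc1`: > 10000 nM

Each of these entries is a limit of the assay and not a number. Compound 2 gives > 10000 nM, and this limit is all that is known of it. Among the compounds with values here, it does not stand apart from the others, for the series so far is summed up by the limit of > 10000 nM in this assay, at which 3 of the 3 values shown sit.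

The next compound is compound 4 `CC(C)(C)n1cc2c(n1)C(=O)CC1(CCN(C(=O)c3cc(N4CCNCC4)nc4ccccc34)CC1)O2`. Its difference from compound 2 is piperazin-1-yl in place of 4-methoxyphenyl on an aromatic carbon. In words, this is piperazin-1-yl in place of 4-methoxyphenyl on an aromatic carbon, next to the ring nitrogen.

The closest measured changes are a step that the two limits leave unreadable from compound 1 to compound 2, a step that the two limits leave unreadable from compound 1 to compound 3 and a step that the two limits leave unreadable from compound 2 to compound 3. None has a readable size, and in all of them the aromatic ring stays, whereas here it leaves. They therefore give no size or direction, and no step beyond the scatter can be firmly expected in this assay. Within the data shown here, compound 4 is expected to stay weak because the limit of > 10000 nM in this assay, at which 3 of the 3 values shown sit, covers every compound measured so far. The estimated change is a step that the limit leaves unreadable from compound 2 to compound 4. For compound 4 the estimate is 15000 nM, with an expected range from 4000 nM to 50000 nM.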

Compound 4, half-maximal inhibitory concentration: 4200 nM
The estimate for compound 4 lay 3.6-fold (0.55 log units) above the measured number; measured number inside the range.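

Among compounds 1, 2 and 3, none of the steps in this assay can be read, so the position on the aromatic carbon next to the ring nitrogen had shown no measurable response to changes on the aryl group there. Replacing the aromatic ring with a non-aromatic one changes that, for piperazin-1-yl in place of 4-methoxyphenyl gives an at least 2.3-fold lower number from compound 2 to compound 4 (0.37 log units; beyond the scatter), in place of 4-(dimethylamino)phenyl gives an at least 2.3-fold lower number from compound 3 to compound 4 (0.37 log units; beyond the scatter), and in place of phenyl gives an at least 2.3-fold lower number from compound 1 to compound 4 (0.37 log units; beyond the scatter); each of these is a minimum size, set by a limit at the starting compound. Compound 4 is thus the only compound shown that yields a number, and the rest of the series stays at the limit: the limit of > 10000 nM in this assay, at which 3 of the 4 values shown sit.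

Going by these compounds, the true size of the gain remains open, and so does the question of whether the free ring amine of piperazin-1-yl matters or any saturated ring at this position would serve. A morpholin-4-yl or 4-methylpiperazin-1-yl group, or an open-chain amine such as 2-aminoethylamino, would separate these possibilities.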